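A few compounds are considered here, and "the series" means these few. Any claim that something is new, unique, unknown or untested is made for them only; others in the source may bear on it.

Two analogues sharing a common core have been measured in a functional assay on HCC78 cells (Homo sapiens) for antiproliferative activity, read by MTT assay, with a stated time of 48 h; on this read-out lower numbers stand for stronger inhibition and higher numbers for weaker inhibition. Compound 1 `COc1cccc(CNC(=O)c2cccc(C(C)Oc3ccnc(Nc4cnn(C)c4)c3)c2)c1` gives 64400 nM in this assay. Within the data shown here, compound 2 `COc1cc(CNC(=O)c2cccc(C(C)Oc3ccnc(Nc4cnn(C)c4)c3)c2)cc(OC)c1OC` gives 73900 nM in this assay, the highest of the two numbers, and its nearest neighbour is compound 1, the only other compound measured. The step from one to the other, a 1.1-fold higher number from compound 1 to compound 2 (0.06 log units; within the scatter), arose from placing 3,4,5-trimethoxyphenyl in place of 3-methoxyphenyl on a saturated chain carbon bound to an amide-type nitrogen, and it stayed within the scatter. Compound 3 `CC(Oc1ccnc(Nc2cnn(C)c2)c1)c1cccc(C(=O)NCc2cc(F)cc(F)c2)c1` has not yet been measured. It differs from compound 2 in one place, (3,5-difluorophenyl in place of 3,4,5-trimethoxyphenyl on a saturated chain carbon bound to an amide-type nitrogen). Among the measured compounds shown here, the only step that bears on this change is the one from compound 1 to compound 2, which altered the same group at the same place and produced no shift beyond the scatter. On that basis the expected step, a 1.1-fold lower number from compound 2 to compound 3 (0.06 log units; within the scatter), is small, with no clear direction. Compound 3 is therefore expected to give about 65000 nM in this assay, within a range from 20000 nM to 200000 nM.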

Compound 3, half-maximal inhibitory concentration: 13200 nM
For compound 3 the middle estimate is 4.9-fold (0.69 log units) above the measured one; the whole stated range lies above it.
By their numbers in this assay, from the lowest: compound 3; then compounds 1 and 2 (each within the scatter of the next).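

At this position, on a saturated chain carbon bound to an amide-type nitrogen, the aryl group can shift the result in this assay after all: putting 3,5-difluorophenyl in place of 3,4,5-trimethoxyphenyl gives a 5.6-fold lower number from compound 2 to compound 3 (0.75 log units; beyond the scatter), and putting it in place of 3-methoxyphenyl gives a 4.9-fold lower number from compound 1 to compound 3 (0.69 log units; beyond the scatter). The earlier pair had suggested a flat position, but it only compared two methoxy-bearing rings, and compound 1 and compound 2 remain within the scatter of each other, so the shift appears only with the change to the fluorinated ring in compound 3. No measurement at hand accounts for this shift.

On these data alone, it remains open whether the lower number belongs to the two fluorines themselves or merely goes with the loss of the methoxy groups, a question that an unsubstituted phenyl or a ring with a single fluorine or chlorine would address. Also open, as far as these compounds go, is whether a dimethylamino group or a carboxylic acid on this ring, or a longer chain in place of the saturated chain carbon, would move the number further from that of compound 3, 13200 nM.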